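The source may report more compounds than this note shows. Statements on the series, on what has been measured and on what is new or still open speak of the compounds shown alone.

Measured compounds:
- compound 1 `COc1cc2cn[nH]c2cc1-c1ccncc1`: > 9300 nM
- compound 2 `COc1cc2c(C(=O)N3CCN(C)CC3)n[nH]c2cc1-c1ccncc1`: 31 nM

In an assay on PBMC cells for antagonist activity at Toll-like receptor 8 (Homo sapiens), with stated times of 30 min and 20 h (a lower number here means a stronger inhibitor, a higher number a weaker inhibitor), compound 2 gives 31 nM. For compound 1 this assay reports only a limit, > 9300 nM. Compound 2 is therefore the only compound with an actual number; the other value is a limit, as shown in the limit of > 9300 nM in this assay, at which 1 of the 2 values shown sits. Within the data shown here, no pair of measured compounds differs in just one place, so no measured step is available to guide the next change.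

Compound 3 `COc1cc2c(C(=O)N3CCN(C)CC3)n[nH]c2cc1-c1ccnc(C)c1F` is not yet measured. It differs from compound 2 by a group of 8 heavy atoms (6 carbon, 1 nitrogen, 1 fluorine; one six-membered aromatic ring with 1 hetero atom) in place of a group of 6 heavy atoms (5 carbon, 1 nitrogen; one six-membered aromatic ring with 1 hetero atom), on an aromatic carbon. Among the measured compounds shown here, nothing among the measured compounds tells how this part of the molecule responds to change, so the expectation for compound 3 rests on compound 2 alone. The change is expected to make a difference no larger than the scatter of this assay, in neither direction with confidence. Compound 3 is therefore estimated at 40 nM in this assay, within a range of 10 nM to 160 nM. That estimate means a step of a 1.3-fold higher number from compound 2 to compound 3 (0.11 log units; within the scatter).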

Compound 3, half-maximal inhibitory concentration in the Toll-like receptor 8 assay: 1.2 nM
The estimate for compound 3 lay 33-fold (1.52 log units) above the measured number, outside the stated range (below it).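

In the Toll-like receptor 8 assay, the aromatic carbon that holds the pyridin-4-yl ring proves highly sensitive to change: a ring with one more carbon and one fluorine in its place gives a 26-fold lower number from compound 2 to compound 3 (1.41 log units; beyond the scatter). So a small addition to this ring, which keeps its single ring nitrogen and adds no charge, can have a large effect on the read-out. The same swap also registers in a physicochemical assay for acid dissociation, where compound 2 gives 5.3 and compound 3 gives 3.7, so that compound 3 gives up its proton more readily: the measured acid dissociation constant of compound 2, 5.3, and of compound 3, 3.7, a number 1.60 log units lower (beyond the scatter).

Among these compounds, with only this one pair, the shift in the Toll-like receptor 8 assay and the shift in proton loss cannot be separated, and the added carbon and the fluorine arrive together, so it remains open which of them carries each step and whether either alone would do the same. From the compounds shown here alone, it is also open how this position responds to a different kind of group, such as a chlorine atom, a nitrile or a morpholine ring in place of the pyridine ring.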